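An amino group added to a compound at the limit

A few compounds are considered here, and "the series" means these few. Any claim that something is new, unique, unknown or untested is made for them only; others in the source may bear on it.

Measured in a functional assay on HeLa cells (Homo sapiens) for antiproliferative activity, read by MTT assay, with a stated time of 48 h; a lower number here means a stronger inhibitor of growth, a higher number a weaker inhibitor of growth:
compound 1 `COc1ccc(/C=C2\Cc3cc(OC)c(OC)c(OC)c3C2=O)cc1[N+](=O)[O-]`: > 10000 nM (a limit)
compound 2 `COc1ccc(/C=C2\Cc3cc(OC)c(OC)c(OC)c3C2=O)cc1`: > 10000 nM (a limit)

In this assay, compound 2 gives > 10000 nM, which is a limit of the assay and not a number. Compound 1 likewise gives only a limit, and the two compounds together make up all the evidence so far: the limit of > 10000 nM in this assay, at which 2 of the 2 values shown sit.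

Compound 3 `COc1ccc(/C=C2\Cc3cc(OC)c(OC)c(OC)c3C2=O)cc1N` differs from compound 2 by one change: amino in place of hydrogen on an aromatic carbon. This places amino in place of hydrogen on an aromatic carbon, ortho to a methoxy group.

Among the measured compounds shown here, the only measured step that bears on this change is a step that the two limits leave unreadable from compound 1 to compound 2, hydrogen in place of nitro on an aromatic carbon. That step has no readable size, so no size can be carried over to the new step. The data allow only a tentative expectation: a step towards stronger growth inhibition in this assay, of open size, with another result at the limit remaining quite possible.

For compound 3 the estimated value is 3000 nM, with an expected range from 100 nM to 20000 nM. This estimate means an expected at least 3.3-fold lower number from compound 2 to compound 3 (0.52 log units; beyond the scatter).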

Compound 3, concentration for 50% growth inhibition: > 10000 nM
Compound 3 ended at the assay's limit (the forecaster's own chance of this, stated with the estimate: 45%); middle value at least 3.3-fold (0.52 log units) from the limit.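

In this assay compound 3 gives > 10000 nM, which is a limit of the assay and not a number. Among the compounds shown here, no step among compound 1, compound 2 and compound 3 can be read, because all three stand at the same limit: the limit of > 10000 nM in this assay, at which 3 of the 3 values shown sit. The compounds shown leave open whether nitro, hydrogen or amino at this place on the shared core differ at all in growth inhibition.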